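The source may report more compounds than this note shows. Statements on the series, on what has been measured and on what is new or still open speak of the compounds shown alone.

Compound 1 `O=C(Nc1cccc(-c2ccsc2)c1)C(Cl)Cl`: > 50000 nM, a limit of the assay
Compound 2 `O=C(Nc1cccc(-c2ccc(-c3ccccc3)cc2)c1)C(Cl)Cl`: 10900 nM
Compound 3 `Cc1ccc(-c2cccc(NC(=O)C(Cl)Cl)c2)cc1`: 8000 nM

In a functional assay on NCI-H460 cells (Homo sapiens) for cytotoxicity, read by MTT assay, with a stated time of 68 h (a lower number here means a stronger inhibitor, a higher number a weaker inhibitor), compound 3 cannot be separated from compound 2, as their values lie within the scatter of each other. Compound 1 gives only a limit. Compound 4 `O=C(Nc1cccc(-c2ccc(C(F)(F)F)cc2)c1)C(Cl)Cl` differs from compound 3 by one change, (trifluoromethyl in place of methyl on an aromatic carbon), with trifluoromethyl in place of methyl on an aromatic carbon, para to a large group. Within the data shown here, the one measured step that bears on it is a 1.4-fold lower number from compound 2 to compound 3 (0.13 log units; within the scatter), so no step beyond the scatter is expected in this assay. The expected step is a 1.1-fold lower number from compound 3 to compound 4 (0.06 log units; within the scatter). For compound 4 the estimated value is 7000 nM, with an expected range of 3000 nM to 18000 nM.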

Compound 4, half-maximal inhibitory concentration: 33600 nM
For compound 4 the middle estimate is 4.8-fold (0.68 log units) below the measured one; measured number outside the range, above it.
By their numbers in this assay, from the lowest: compounds 3 and 2 (each within the scatter of the next); then compound 4. At a limit, above all of these: compound 1.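

In this assay, among these compounds, the earlier compounds showed no separation between methyl and phenyl at this position, so the group there might have seemed to matter little. Trifluoromethyl changes that, with a 4.2-fold higher number from compound 3 to compound 4 (0.62 log units; beyond the scatter) and a 3.1-fold higher number from compound 2 to compound 4 (0.49 log units; beyond the scatter), so the position does respond to the group it carries. Nothing given here accounts for this loss of cytotoxic strength.

The compounds shown leave open how an amine, a methoxy group or a carboxylic acid at this position would compare with methyl and trifluoromethyl.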